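Trading the phenyl ether for a methyl ether on the shared core

The source may report more compounds than this note shows. Statements on the series, on what has been measured and on what is new or still open speak of the compounds shown alone.

Measured compounds:
compound 1 `CCCN1CCCN(c2nc3ccccc3n2CCOCC)CC1`, 8.4 nM in a functional assay on ileum for inhibition of histamine H1 receptor (Cavia porcellus); on this read-out higher numbers stand for weaker inhibition and lower numbers for stronger inhibition
compound 2 `CN1CCN(c2nc3ccccc3n2CCOc2ccccc2)CC1`, 6.9 nM
compound 3 `CN1CCCN(c2nc3ccccc3n2CCOc2ccccc2)CC1`, 9.1 nM

Among these three, compound 2 holds the lowest number, though compound 1 and compound 3 both sit within the scatter of it. For the measured compounds named here, the one single-point step on record, a 1.3-fold higher number from compound 2 to compound 3 (0.12 log units; within the scatter), swaps the ring attached to the core and leaves the ether untouched.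

Compound 4 `COCCn1c(N2CCN(C)CC2)nc2ccccc21` differs from compound 2 as follows: methyl in place of phenyl on an oxygen on a saturated carbon. Going by the values given here, no measured step isolates this phenoxy-to-methoxy exchange. The nearest hint comes from compound 1, which carries an ethyl on that oxygen and gives 8.4 nM, while compound 3, which carries the phenyl there, gives 9.1 nM; these two differ in a second place as well, yet their numbers lie within the scatter of each other. The small alkyl ether therefore seems tolerated, and no step beyond the scatter is expected for a 1.2-fold higher number from compound 2 to compound 4 (0.06 log units; within the scatter). Compound 4 is accordingly estimated at 8 nM, within 3.5 nM to 18 nM.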

Compound 4, half-maximal inhibitory concentration: 13 nM
The estimate for compound 4 lay 1.6-fold (0.21 log units) below the measured number; the measured number falls inside the stated range.
By their numbers in this assay, from the lowest: compounds 2, 1, 3 and 4 (each within the scatter of the next).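

In this assay the exchange of phenoxy for methoxy gives a 1.9-fold higher number from compound 2 to compound 4 (0.28 log units; within the scatter), the only direct reading of this position among the compounds shown. With the 4-methylpiperazin-1-yl ring held fixed, the step stays within the scatter, so methyl on this oxygen is not told apart from phenyl, even though one six-membered aromatic ring leaves with the change. No available evidence bears on this result.

On these data alone, it remains open whether a longer chain such as butyl, or a chain ending in an amine, on this oxygen would also stay within the scatter of compound 2. It is equally unsettled whether methoxy would behave the same way alongside the 4-methyl-1,4-diazepan-1-yl ring of compound 3.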